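Changing one side chain on compound 1

The source may hold more compounds than are shown below. What is called first, only, known or untested is meant among the compounds shown, and "the series" means these compounds.

Going by the values given here, in a functional assay on Caco-2 cells (Homo sapiens), read by MTT assay, with a stated time of 48 h (on this read-out lower numbers stand for stronger inhibition and higher numbers for weaker inhibition), compound 1 (`CCN(CC)CCCNC(=O)c1ccc(C(CC)(CC)c2ccc(OCC(=O)C(C)(C)C)c(C)c2)n1CC`) gives 1000 nM and is one of only two measured compounds. In this assay compound 2 (`CCN(CC)CCCNC(=O)c1ccc(C(CC)(CC)c2ccc(OCC(O)C(C)(C)C)c(C)c2)n1CC`) gives 1800 nM and so cannot be told apart from compound 1. Compound 3 (`CCn1c(C(=O)N(C)CC(=O)O)ccc1C(CC)(CC)c1ccc(OCC(=O)C(C)(C)C)c(C)c1`) keeps the (tert-butyl)carbonyl group of compound 1. It instead carries (carboxymethyl)(methyl)amino in place of (3-(diethylamino)propyl)amino on a carbonyl carbon. Among the compounds with values here, the only measured step is a 1.8-fold higher number from compound 1 to compound 2 (0.26 log units; within the scatter) and it lies within the scatter. That step replaces (tert-butyl)carbonyl with 1-hydroxy-2,2-dimethylpropyl, a different change in a different place, so it offers no direct guide here. Within the data shown here, no measured compound carries the new group, and a real shift in either direction is possible. A modest lean towards a lower number is only a judgement, without measured support. The expected step is a 2.0-fold lower number from compound 1 to compound 3 (0.30 log units; within the scatter) as a rough estimate with wide uncertainty. For compound 3 the estimated value is 500 nM with an expected range from 40 nM to 5000 nM in this assay for now.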

Compound 3, half-maximal inhibitory concentration: 35900 nM
The estimate for compound 3 lay 72-fold (1.86 log units) below the measured number, and the stated range ends below it.
By their numbers in this assay, from the lowest: compounds 1 and 2 (each within the scatter of the next); then compound 3.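

In this assay, going by these compounds alone, the group on the carbonyl carbon matters far more than the earlier compounds could show: swapping (3-(diethylamino)propyl)amino for (carboxymethyl)(methyl)amino gives a 36-fold higher number from compound 1 to compound 3 (1.56 log units; beyond the scatter) and this large step stands in contrast to the only earlier one, a 1.8-fold higher number from compound 1 to compound 2 (0.26 log units; within the scatter) made at a different place. The swap is not a single small edit, since the entering group is shorter by the count of heavy atoms, loses the diethylamino end and brings in a carboxylic acid and a methyl on the nitrogen, so these parts cannot be separated with the compounds shown. The data at hand offer no measured explanation for why the number rises so far.

Still open is which of these parts accounts for the step: a carboxylic acid on a longer propyl chain with the nitrogen methyl absent, or a short chain ending in a dimethylamine, would begin to pull them apart. Also open, going by these compounds, is whether the small difference seen between the (tert-butyl)carbonyl and 1-hydroxy-2,2-dimethylpropyl side chains would hold when the carboxymethyl group is present.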